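Chloro for Fluoro on Compound 2

The source may hold more compounds than are shown below. What is called first, only, known or untested is meant among the compounds shown, and "the series" means these compounds.

- Compound 1 `O=C(NN1Cc2ccccc2C1)c1ccccc1F`: 241000 nM
- Compound 2 `O=C(NN1Cc2ccccc2C1)c1cc([N+](=O)[O-])ccc1F`: > 331000 nM (a limit)

In an ADME assay on L6 cells (Rattus norvegicus) for cytotoxicity (a lower number here means a stronger inhibitor, a higher number a weaker inhibitor), compound 2 has only a limit, > 331000 nM, and not a number. Compound 3 `O=C(NN1Cc2ccccc2C1)c1cc([N+](=O)[O-])ccc1Cl` carries one change from compound 2: chloro in place of fluoro on an aromatic carbon. Among the measured compounds shown here, the only measured step, an at least 1.3-fold higher number from compound 1 to compound 2 (0.13 log units; that floor lies within the scatter), is nitro in place of hydrogen, so it says nothing direct about chloro in place of fluoro. No clear step in either direction is therefore expected in this assay. The estimated step is an at least 1.1-fold lower number from compound 2 to compound 3 (0.04 log units; that floor lies within the scatter). Compound 3 is expected at about 300000 nM, with an estimated range of 150000 nM to 500000 nM.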

Compound 3, half-maximal inhibitory concentration: 19800 nM
The estimate for compound 3 lay 15-fold (1.18 log units) above the measured number, outside the stated range (below it).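

In this assay, exchanging one single atom for another at this position, ortho to a large group and para to a nitro group, is far from a neutral swap: chloro in place of fluoro gives an at least 16-fold lower number from compound 2 to compound 3 (1.22 log units; beyond the scatter). Among the compounds shown here, this is the first clear step, and it shows that the atom on this carbon matters for the read-out. Compound 2 has only a limit and not a number, so the step is a floor and its true size stays unknown: the limit of > 331000 nM in this assay, at which 1 of the 3 values shown sits.

The compounds shown leave open whether chloro would give a step of similar size without the nitro group. They also leave open whether a methoxy group or an amine at this position would move the number too.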